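Aryl amide swap in the shared-core series: compound 3

The source may report more compounds than this note shows. Statements on the series, on what has been measured and on what is new or still open speak of the compounds shown alone.

Compound 1 `COc1ccc2c(=O)c(/C=C/C(=O)Nc3cccc(Cl)c3)coc2c1` is the reference point. In a functional assay on L02 cells (Homo sapiens) for inhibition, read by MTT assay, with a stated time of 48 h (on this read-out lower numbers stand for stronger inhibition and higher numbers for weaker inhibition), compound 1 gives only a limit of the assay, > 200000 nM, so its standing on the numbers is a limit and nothing more. Compound 2 `COc1ccc2c(=O)c(/C=C/C(=O)NCc3ccccc3)coc2c1` carries benzyl in place of 3-chlorophenyl on the amide-type nitrogen. In this assay compound 2 also gives only a limit, > 200000 nM. The step that the two limits leave unreadable from compound 1 to compound 2 therefore cannot be sized, and the limit of > 200000 nM in this assay, at which 2 of the 2 values shown sit, is the whole of the measured record at this position.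

Compound 3 `COc1ccc2c(=O)c(/C=C/C(=O)Nc3cc(C)ccc3C)coc2c1` carries 2,5-dimethylphenyl in place of 3-chlorophenyl on an amide-type nitrogen. Within the data shown here, the only measured step at this nitrogen, a step that the two limits leave unreadable from compound 1 to compound 2, is unreadable, so no direction beyond the scatter can be drawn for the new change. Compound 3 is expected to remain at or near the limit in this assay, with an estimated step of a number no higher from compound 1 to compound 3 (the limit leaves the size open). The estimate for compound 3 is 200000 nM, with an expected range from 80000 nM to 600000 nM.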

Compound 3, half-maximal inhibitory concentration: > 200000 nM
Compound 3: no number, only a limit (the forecaster's own chance of this, stated with the estimate: 85%); the middle value sits exactly at the limit.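

Compound 3 adds no readable step from compound 1 or compound 2 in this assay, where all three compounds give only a limit: the limit of > 200000 nM in this assay, at which 3 of the 3 values shown sit.

The compounds shown leave open whether any group on this amide-type nitrogen gives a measurable value in this assay, and how large the steps among them are.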